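The source may hold more compounds than are shown below. What is called first, only, known or untested is meant among the compounds shown, and "the series" means these compounds.

Working notes on the series. In a functional assay on U2OS cells (Homo sapiens) for cytotoxicity, read by MTT assay, with a stated time of 48 h (on this read-out lower numbers stand for stronger inhibition and higher numbers for weaker inhibition), compound 1 `Fc1cccc(-c2nc(Nc3ccccc3)c3ccccc3n2)c1` returns only the limit > 50000 nM, not a number. Compound 2 `Fc1cccc(-c2nc(Nc3cccc(Cl)c3)c3cc(F)ccc3n2)c1` likewise gives only the limit > 50000 nM in this assay. Among the compounds with values here, both values therefore sit at the limit of > 50000 nM in this assay, at which 2 of the 2 values shown sit, so compound 2 stands level with compound 1 and no step between them can be counted. Compound 3 `Nc1cccc(Nc2nc(-c3cccc(F)c3)nc3ccc(F)cc23)c1` carries amino in place of chloro on an aromatic carbon. With both neighbours at the limit, no step beyond the scatter is expected from compound 2 to compound 3, and the estimated change a step that the limit leaves unreadable from compound 2 to compound 3 is taken as flat. Compound 3 is expected at 60000 nM, with a range from 15000 nM to 200000 nM, most likely again reported as a limit.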

Compound 3, half-maximal inhibitory concentration: 49700 nM
The estimate for compound 3 lay 1.2-fold (0.08 log units) above the measured number, and the stated range covers the measured number.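

In this assay, amino in place of chloro on an aromatic carbon, meta to a large group, gives a number no higher from compound 2 to compound 3 (the limit leaves the size open). Within the data shown here, compound 3 is thus the first compound here to return a number rather than a limit, so this position can be read in this assay once it carries amino. Most of the series still stands at the limit: the limit of > 50000 nM in this assay, at which 2 of the 3 values shown sit.

Going by these compounds, the true size of this step stays open. So does whether an acetamide, a dimethylamino group or a carboxylic acid at this position would move the number further.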